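This account rests on a few compounds, and the source may have more. Where it says the series, first, only, none or still open, it means among the compounds named here.

Measured in a functional assay on U-87MG ATCC cells for antiproliferative activity against U-87 MG (Homo sapiens), read by MTT assay, with a stated time of 48 h; a lower number here means a stronger inhibitor, a higher number a weaker inhibitor:
- Compound 1 `Cc1nc(-c2ccc(Cl)cc2)sc1C(=O)CSc1nc(-c2ccc(Cl)c(Cl)c2)c(C#N)c(=O)[nH]1`: 83900 nM
- Compound 2 `Cc1nc(-c2ccc(Cl)cc2)sc1C(=O)CSc1nc(-c2ccc(Cl)cc2)c(C#N)c(=O)[nH]1`: 53000 nM

With only these two numbers, compound 2, at 53000 nM, cannot be told apart from compound 1. The next compound, compound 3 `COc1cccc(-c2nc(SCC(=O)c3sc(-c4ccc(Cl)cc4)nc3C)[nH]c(=O)c2C#N)c1`, keeps the shared core but carries 3-methoxyphenyl in place of 4-chlorophenyl on an aromatic carbon.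

Within the data shown here, one measured step bears on this aryl group, the swap of a chloro for hydrogen between compound 1 and compound 2: a 1.6-fold lower number from compound 1 to compound 2 (0.20 log units; within the scatter). That gives a hint that this group may tolerate change in this assay. Among the measured compounds shown here, no measured compound carries a methoxy group, however, so the data favour no direction, and no change beyond the scatter is expected.

Compound 3 is expected at about 50000 nM.
The estimated range runs from 20000 nM to 120000 nM.
This estimate means an expected 1.1-fold lower number from compound 2 to compound 3 (0.03 log units; within the scatter).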

Compound 3, half-maximal inhibitory concentration: 41000 nM
Estimate against measurement, compound 3: 1.2-fold (0.09 log units) above; the measured number falls inside the stated range.
By their numbers in this assay, from the lowest: compounds 3, 2 and 1 (each within the scatter of the next, the first and the last beyond it).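

In this assay, putting 3-methoxyphenyl in place of 4-chlorophenyl gives a 1.3-fold lower number from compound 2 to compound 3 (0.11 log units; within the scatter), so a ring with a methoxy group and no chlorine cannot be told apart from the 4-chlorophenyl compound. Among these compounds, putting 3-methoxyphenyl in place of 3,4-dichlorophenyl gives a 2.0-fold lower number from compound 1 to compound 3 (0.31 log units; beyond the scatter), the first step at this aromatic carbon to pass the scatter, though only modestly. This position therefore accepts an oxygen-bearing substituent on the aryl ring across these three compounds, and nothing available accounts for these small differences.

The compounds shown leave open whether the methoxy group's place on the ring matters, as a 4-methoxyphenyl group would test. They also leave open how this position would respond to an aryl ring carrying an amine or a carboxylic acid, or to a longer chain in place of the ring.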